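This account rests on a few compounds, and the source may have more. Where it says the series, first, only, none or still open, it means among the compounds named here.

Of the compounds shown here, three sharing one core have been measured for cytotoxicity. Compound 1 `COc1ccc(/C=N/NC(=O)Nc2ccc(Oc3ccnc(-c4nncn4CCN(C)C)c3)c(F)c2)c(OC)c1` gives 2820 nM in a functional assay on A549 cells (Homo sapiens) for cytotoxicity, read by MTT assay, with a stated time of 72 h; on this read-out lower numbers stand for stronger inhibition and higher numbers for weaker inhibition. Compound 2 `CN(C)CCn1cnnc1-c1cc(Oc2ccc(NC(=O)N/N=C/c3ccccc3O[N+](=O)[O-])cc2F)ccn1` gives 1200 nM in this assay, and compound 3 `CN(C)CCn1cnnc1-c1cc(Oc2ccc(NC(=O)N/N=C/c3cccc(Cl)c3Cl)cc2F)ccn1` gives 1090 nM in this assay. The steps seen were a 2.4-fold lower number from compound 1 to compound 2 (0.37 log units; beyond the scatter) and a 2.6-fold lower number from compound 1 to compound 3 (0.41 log units; beyond the scatter), whereas a 1.1-fold lower number from compound 2 to compound 3 (0.04 log units; within the scatter). Compound 3 thus has the lowest number of the three, though its gap to compound 2 is within the scatter. Compound 4 `CN(C)CCn1cnnc1-c1cc(Oc2ccc(NC(=O)N/N=C/c3cc(Br)c(O)c(Br)c3)cc2F)ccn1` differs from compound 3 by 3,5-dibromo-4-hydroxyphenyl in place of 2,3-dichlorophenyl on a carbon with a double bond to nitrogen. Going by the values given here, no measured step swaps in a ring bearing a hydroxyl, so the expectation rests on the general picture that changing this ring has moved numbers only modestly, as a 1.1-fold lower number from compound 2 to compound 3 (0.04 log units; within the scatter) shows; the estimated step is a 1.2-fold higher number from compound 3 to compound 4 (0.08 log units; within the scatter). Compound 4 is therefore expected to give about 1300 nM in this assay, within 500 nM to 3500 nM.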

Compound 4, half-maximal inhibitory concentration: > 100000 nM
Compound 4 ended at the assay's limit; the forecaster's own chance of this, stated with the estimate: 5%; at least 76-fold (1.88 log units) between middle value and limit.
By their numbers in this assay, from the lowest: compounds 3 and 2 (each within the scatter of the next); then compound 1. At a limit, above all of these: compound 4.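

Going by these compounds alone, the ring on the carbon with a double bond to nitrogen had so far moved the numbers only modestly, but 3,5-dibromo-4-hydroxyphenyl brings large steps: an at least 91-fold higher number from compound 3 to compound 4 (1.96 log units; beyond the scatter), an at least 83-fold higher number from compound 2 to compound 4 (1.92 log units; beyond the scatter) and an at least 35-fold higher number from compound 1 to compound 4 (1.54 log units; beyond the scatter). So a change at this position can nearly abolish cytotoxicity in this series, not merely tune it. Compound 4 stands at a limit of the assay, not at a true number: the limit of > 100000 nM in this assay, at which 1 of the 4 values shown sits.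

The compounds shown leave open whether the hydroxyl, the two bromines or their combination goes with this loss. A 4-hydroxyphenyl ring and a 3,5-dibromophenyl ring would separate them.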